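Terminal group exchange on the chain of the shared core

This account rests on a few compounds, and the source may have more. Where it says the series, first, only, none or still open, it means among the compounds named here.

Compound 1 `CCCCN1CCN(CCCCn2c3c(c4ccccc42)C(=O)c2c[n+]([O-])c4ccccc4c2C3=O)CC1` gives 2150 nM in a functional assay on A-375 cells (Homo sapiens) for cytotoxicity, read by MTT assay, with a stated time of 72 h; a higher number here means a weaker inhibitor, a lower number a stronger inhibitor. Compound 2 `CN(C)CCCCCn1c2c(c3ccccc31)C(=O)c1c[n+]([O-])c3ccccc3c1C2=O` gives 560 nM in this assay. Going by the values given here, the one measured step, a 3.8-fold lower number from compound 1 to compound 2 (0.58 log units; beyond the scatter), exchanges the group at the end of the chain. Among the compounds with values here, on these two numbers compound 2 stands lowest, with compound 1 the only neighbour and its number the higher one.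

Compound 3 `O=C1c2c[n+]([O-])c3ccccc3c2C(=O)c2c1c1ccccc1n2CCCCn1ccnc1` has not been measured. It differs from compound 2 by 1H-imidazol-1-yl in place of (dimethylamino)methyl on a saturated chain carbon, four bonds along the chain from an aromatic nitrogen. Within the data shown here, the only step that bears on it is the exchange at this same place, a 3.8-fold lower number from compound 1 to compound 2 (0.58 log units; beyond the scatter), a modest move. Among the measured compounds shown here, no measured pair shows what an imidazolyl ring does here, so the direction of the new step cannot be read from the numbers; the size is expected to be similar, with the scatter leaving a change of either sign possible.

For compound 3 a number near that of compound 2 is therefore expected, estimated at 900 nM within 350 nM to 2500 nM, which corresponds to an expected step of a 1.6-fold higher number from compound 2 to compound 3 (0.21 log units; within the scatter).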

Compound 3, half-maximal inhibitory concentration: 350 nM
Compound 3: middle estimate off by 2.6-fold (0.41 log units), on the high side; the range from low to high includes it.
By their numbers in this assay, from the lowest: compounds 3 and 2 (each within the scatter of the next); then compound 1.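

In this assay, exchanging the end group of the chain for the 1H-imidazol-1-yl ring gives a 1.6-fold lower number from compound 2 to compound 3 (0.20 log units; within the scatter) and so does not separate the two end groups: this position accepts a five-membered aromatic ring as well as an open dimethylamino end. Against 4-butylpiperazin-1-yl, the same ring gives a 6.1-fold lower number from compound 1 to compound 3 (0.79 log units; beyond the scatter) at this place, so compound 1 now stands apart from two different end groups rather than from one alone. Nothing measured here gives a reason for these steps.

On these data alone, whether the step away from compound 1 belongs to the butyl group or to the piperazine ring itself stays open, and a piperazine without the butyl group or a morpholine at the chain end would address this. Also open, as far as these compounds go, are a shorter or longer chain carrying the 1H-imidazol-1-yl ring, and a chain ending in a carboxylic acid or a primary amine.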